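The source may report more compounds than this note shows. Statements on the series, on what has been measured and on what is new or still open speak of the compounds shown alone.

Of the compounds shown here, three have been tested in a functional assay on K562 cells (Homo sapiens) for inhibition, read by sulforhodamine B assay, with a stated time of 48 h; a higher number here means a weaker inhibitor of growth, a lower number a stronger inhibitor of growth: compound 1 `CCOC(=O)c1nn(-c2ccc(Cl)cc2)c(-c2ccc([N+](=O)[O-])cc2)c1CNC(C)(C)C`, compound 2 `CC(C)(C)NCc1c(C(=O)O)nn(-c2ccccc2)c1-c1ccc([N+](=O)[O-])cc1` and compound 3 `COc1ccc(-c2c(CNC(C)(C)C)c(C(=O)O)nn2-c2ccc(Cl)cc2)cc1`. Only compound 1 has numerical results, and in this assay compound 1 gives 181000 nM; 14800 nM (2 entries), two entries that lie far apart. Compound 2 reads > 634000 nM, which is a limit and not a number. Compound 3 reads > 605000 nM, which is also a limit, so compound 3 has no measured value and stands only at that limit.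

The compound still to be measured, compound 4 `CC(C)(C)NCc1c(C(=O)O)nn(-c2ccc(Cl)cc2)c1-c1ccc([N+](=O)[O-])cc1`, differs from compound 3 at one place: nitro in place of methoxy on an aromatic carbon. This is nitro in place of methoxy on an aromatic carbon, para to a large group, so that 4-methoxyphenyl becomes 4-nitrophenyl. Going by the values given here, no measured pair of compounds shows what this change does in this assay.

Resting on the limit of compound 3 at > 605000 nM, no step beyond the scatter is expected in this assay, and another limit is the most likely report. The estimate amounts to an at least 1.1-fold lower number from compound 3 to compound 4 (0.04 log units; that floor lies within the scatter), which is expected to stay within the usual scatter. For compound 4 the estimated value is 550000 nM, with an expected range from 150000 nM to 800000 nM.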

Compound 4, concentration for 50% growth inhibition: 158000 nM
Estimate against measurement, compound 4: 3.5-fold (0.54 log units) above, and the stated range covers the measured number.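

With the carboxylic acid kept on the shared core, compound 4 is the only one of the three acids that gives a number in this assay, reading 158000 nM. On an aromatic carbon para to a large group, nitro in place of methoxy gives an at least 3.8-fold lower number from compound 3 to compound 4 (0.58 log units; beyond the scatter), so the change now has a measured lower bound on its size, and that bound is all it has, since the step starts from a limit. Chloro in place of hydrogen on an aromatic carbon gives an at least 4.0-fold lower number from compound 2 to compound 4 (0.60 log units; beyond the scatter), also from a limit, so among these acids a number appears only where nitro and chloro occur together, and neither change alone gives one.

On these data alone, whether the ethyl ester of compound 1 reads differently from the acid of compound 4 stays unsettled, as the entries of compound 1 disagree with each other: the several entries of compound 1 in this assay, 181000 nM; 14800 nM (2 entries) It also remains open whether an amine or a nitrile in the place of the nitro group, or bromo or methyl in the place of the chloro group, would give a similar result.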